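A Methyl on the Phenyl of Compound 1

A few compounds are considered here, and "the series" means these few. Any claim that something is new, unique, unknown or untested is made for them only; others in the source may bear on it.

Compound 1 `O=C(NOCc1ccccc1F)c1cn(-c2ccccc2)nc1-c1ccccc1` carries a shared core with a phenyl group and an amide whose oxygen is bound to a chain ending in a 2-fluorophenyl ring. In a functional assay on HeLa cells (Homo sapiens) for antiproliferative activity, read by MTT assay, with a stated time of 48 h, in the presence of a further agent that is not named here (a higher number here means a weaker inhibitor of growth, a lower number a stronger inhibitor of growth), compound 1 gives 11800 nM, the second highest of the three measured numbers. Compound 2 `O=C(NOCc1ccccc1Cl)c1cn(-c2ccccc2)nc1-c1ccccc1` gives 17800 nM, and the step of a 1.5-fold higher number from compound 1 to compound 2 (0.18 log units; within the scatter) stays within the scatter. Compound 3 `O=C(NOCc1ccc(Cl)cc1Cl)c1cn(-c2ccccc2)nc1-c1ccccc1` gives 5100 nM; the step of a 2.3-fold lower number from compound 1 to compound 3 (0.36 log units; beyond the scatter) is modest, and so is a 3.5-fold lower number from compound 2 to compound 3 (0.54 log units; beyond the scatter).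

Compound 4 `Cc1ccc(-c2nn(-c3ccccc3)cc2C(=O)NOCc2ccccc2F)cc1` differs from compound 1 by methyl in place of hydrogen on an aromatic carbon. Every measured step alters the ring on the chain bound to oxygen, not the phenyl on the core, so none of them bears on this change. With nothing to point in either direction, no step beyond the scatter is expected. Compound 4 is therefore estimated at 11800 nM, with a range from 4000 nM to 35000 nM. That estimate means a step of no change at the digits printed from compound 1 to compound 4 (within the scatter).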

Compound 4, concentration for 50% growth inhibition: 1180 nM
For compound 4 the middle estimate is 10-fold (1.00 log units) above the measured one; the whole stated range lies above it.
By their numbers in this assay, from the lowest: compound 4; then compound 3; then compounds 1 and 2 (each within the scatter of the next).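

The phenyl on the shared core, untouched by all the earlier changes, proves to be a place where this assay responds strongly: the step of a 10-fold lower number from compound 1 to compound 4 (1.00 log units; beyond the scatter) comes from a single added carbon, giving a 4-methylphenyl group. That step is larger in size than the biggest step seen on the ring at the end of the chain, a 3.5-fold lower number from compound 2 to compound 3 (0.54 log units; beyond the scatter), so the core phenyl cannot be treated as a passive part of the structure. Nothing available here explains how this methyl produces the gain.

As far as these compounds go, with only one substituent at this place, it remains open whether an ethyl, a methoxy group or a carboxylic acid there would act as methyl does. From the compounds shown here alone, it is also open whether this gain would add to that of the 2,4-dichlorophenyl ring of compound 3 if both changes were combined.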